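Swapping a bromine for a benzyl group on an inhibitor of indoleamine 2,3-dioxygenase 1

A few compounds are considered here, and "the series" means these few. Any claim that something is new, unique, unknown or untested is made for them only; others in the source may bear on it.

Compound 1 `O/N=C(/Nc1cccc(Br)c1)c1ccc2occc2c1` is the strongest of three compounds measured in an assay on tissue (HeLa cells) for inhibition of Indoleamine 2,3-dioxygenase 1 (Homo sapiens), read by spectrophotometry (a higher number here means a weaker inhibitor, a lower number a stronger inhibitor), where compound 1 gives 1100 nM. Its nearest neighbour is compound 3 `O/N=C(/Nc1ccc(F)c(Br)c1)c1ccc2occc2c1`, which in this assay gives 2600 nM; the furthest is compound 2 `O/N=C(/Nc1ccc(F)c(F)c1)c1ccc2occc2c1`, which gives 14000 nM. Two single-point steps connect these three. Adding a fluoro in place of hydrogen on an aromatic carbon gives a 2.4-fold higher number from compound 1 to compound 3 (0.37 log units; beyond the scatter), and putting bromo in place of fluoro on an aromatic carbon gives a 5.4-fold lower number from compound 2 to compound 3 (0.73 log units; beyond the scatter). Both steps are modest, and both show that the halogen pattern on the aniline ring moves the number.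

Compound 4 `O/N=C(/Nc1cccc(Cc2ccccc2)c1)c1ccc2occc2c1` takes a different route: benzyl in place of bromo on an aromatic carbon. Within the data shown here, no measured step exchanges a halogen for a carbon group, so the two steps above offer only indirect guidance. They do show that this ring position tolerates change without collapse in potency, yet the benzyl group is much larger than anything tried so far. The expectation is therefore a step of a 2.3-fold higher number from compound 1 to compound 4 (0.36 log units; beyond the scatter), towards a somewhat weaker inhibitor, with wide uncertainty. Compound 4 is expected to give about 2500 nM in this assay, plausibly between 600 nM and 12000 nM.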

Compound 4, half-maximal inhibitory concentration: > 30000 nM
Compound 4 was reported as a limit; the forecaster's own chance of this, stated with the estimate: 5%; middle value at least 12-fold (1.07 log units) away from the limit.
By their numbers in this assay, from the lowest: compound 1; then compound 3; then compound 2. At a limit, above all of these: compound 4.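

The halogen steps at this position stayed modest, but exchanging bromo for benzyl on this aromatic carbon gives the only large step among the compounds shown, an at least 27-fold higher number from compound 1 to compound 4 (1.43 log units; beyond the scatter). The tolerance seen with fluoro and bromo therefore does not extend to every group: a single change here, from one heavy atom to seven and a six-membered aromatic ring, is enough to take compound 4 out of the range that this assay can put a number on. Compound 4 is reported only as a limit, not as a number, so its true value and the full size of the step stay unknown: the limit of > 30000 nM in this assay, at which 1 of the 4 values shown sits.

One exchange cannot separate the contributions of the added ring, the number of heavy atoms and the carbon link that joins the ring to the core. Whether a methyl, an ethyl, a methoxy or an amine on this same carbon keeps a measurable number, and whether a phenyl ring joined directly behaves as benzyl does, remains an open question.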